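Methyl in place of chloro: compound 3 to compound 4

The source may report more compounds than this note shows. Statements on the series, on what has been measured and on what is new or still open speak of the compounds shown alone.

In a functional assay on P388 cells (Mus musculus) for inhibition (on this read-out higher numbers stand for weaker inhibition and lower numbers for stronger inhibition), compound 3 `O=C1CCCCC/C1=C\c1cccc(Cl)c1` gives 25700 nM. Compound 1 `Cc1cccc(/C=C2\CCCc3ccccc3C2=O)c1` gives 19900 nM, and the two values lie within the scatter of each other. Compound 2 `O=C1CCCCC/C1=C\c1cccc(F)c1` reads > 50000 nM, which is a limit of the assay and not a number.

The next compound, compound 4 `Cc1cccc(/C=C2\CCCCCC2=O)c1`, departs from compound 3 as follows: methyl in place of chloro on an aromatic carbon. In words, this is methyl in place of chloro on an aromatic carbon.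

Going by the values given here, only one measured step swaps one group for another on an aromatic carbon, chloro in place of fluoro, and it gives an at least 1.9-fold lower number from compound 2 to compound 3 (0.28 log units; that floor lies within the scatter). It starts from a limit and its floor stays within the scatter, so it sets no size for the present change. Compound 1 offers a second, indirect pointer: it carries a methyl on a different core and reads 19900 nM. Nothing measured therefore points to a clear shift in either direction in this assay. The expected change is a 1.1-fold higher number from compound 3 to compound 4 (0.04 log units; within the scatter), an estimated step that does not go beyond the scatter. Compound 4 could also end up at the limit of > 50000 nM in this assay, at which 1 of the 3 values shown sits. For compound 4 the estimated value is 28000 nM, with an expected range from 14000 nM to 50000 nM.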

Compound 4, half-maximal inhibitory concentration: 29800 nM
Estimate against measurement, compound 4: 1.1-fold (0.03 log units) below; measured number inside the range.
By their numbers in this assay, from the lowest: compounds 1, 3 and 4 (each within the scatter of the next). At a limit, above all of these: compound 2.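

In this assay, methyl and chloro can now be compared directly on the same core at this position, which compound 1, on a different core, could not offer: the swap gives a 1.2-fold higher number from compound 3 to compound 4 (0.06 log units; within the scatter). At this position, then, methyl in place of chloro produces no shift beyond the scatter, and the two groups cannot be told apart on this read-out. The comparison with fluoro gives only an at least 1.6-fold lower number from compound 2 to compound 4 (0.22 log units; that floor lies within the scatter), so it sets no size for that change, and compound 2 remains a limit and not a number: the limit of > 50000 nM in this assay, at which 1 of the 4 values shown sits.

As far as these compounds go, how an amine, a hydroxyl or a carboxylic acid on this aromatic carbon would read remains open, as does whether any group here can give a step beyond the scatter. Also open, from the compounds shown here alone, is whether methyl and chloro would read alike on the core of compound 1, which appears here with methyl only.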